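A few compounds are considered here, and "the series" means these few. Any claim that something is new, unique, unknown or untested is made for them only; others in the source may bear on it.

In a functional assay on KM12 cells (Homo sapiens) for inhibition, read by sulforhodamine B assay, with a stated time of 96 h; on this read-out higher numbers stand for weaker inhibition of growth and lower numbers for stronger inhibition of growth:
- Compound 1 `CC[C@@H](Nc1nc(NCc2ccccn2)c2ncn(C(C)C)c2n1)C(C)O`: 37000 nM
- Compound 2 `CC[C@@H](Nc1nc(NCc2ccccn2)c2ncn(C(C)C)c2n1)C(O)C(C)(C)C`: 45000 nM

Within the data shown here, compound 1 lies within the scatter of compound 2, the only other compound measured. Compound 3 `CC[C@H](Nc1nc(NCc2ccccn2)c2ncn(C(C)C)c2n1)C(O)C(C)(C)C` is still unmeasured, and its change from compound 1 reads: 1-ethyl-2-hydroxy-3,3-dimethylbutyl in place of 1-(1-hydroxyethyl)propyl on a nitrogen on an aromatic ring. Among the measured compounds shown here, the one measured step that bears on it, tert-butyl in place of methyl on the chain, is small: a 1.2-fold higher number from compound 1 to compound 2 (0.09 log units; within the scatter). For the measured compounds named here, no measured step shows what the handedness of the defined stereocentre in compound 3 contributes, so the range is kept wide. The expected step is a 1.1-fold higher number from compound 1 to compound 3 (0.03 log units; within the scatter), nothing beyond the scatter in this assay. For compound 3 the estimated value is 40000 nM, expected to fall between 15000 nM and 85000 nM.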

Compound 3, concentration for 50% growth inhibition: 36000 nM
The estimate for compound 3 lay 1.1-fold (0.05 log units) above the measured number, and the stated range covers the measured number.
By their numbers in this assay, from the lowest: compounds 3, 1 and 2 (each within the scatter of the next).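

In this assay, the change to 1-ethyl-2-hydroxy-3,3-dimethylbutyl on the nitrogen gives a 1.0-fold lower number from compound 1 to compound 3 (0.01 log units; within the scatter), and the change in drawn configuration at the saturated chain carbon gives a 1.3-fold lower number from compound 2 to compound 3 (0.10 log units; within the scatter). Thus, neither the change of chain nor this change of drawn configuration moves the number beyond the scatter. The configuration comparison carries one limit: the fact that one of compounds 2 and 3 is drawn with a defined configuration and the other without, at the place where they differ

The compounds shown leave open whether an amine or a carboxylic acid in place of the hydroxyl, or a longer chain, would give a step beyond the scatter. None of the steps shown at this position goes beyond it.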